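The source may hold more compounds than are shown below. What is called first, only, known or untested is meant among the compounds shown, and "the series" means these compounds.

Measured so far in an assay on membranes from HeLa cells for displacement of a labelled ligand from adenosine receptor A3 (Homo sapiens), read by scintillation counting, with a stated time of 180 min, tested at 1 uM; a lower number here means less inhibition, a higher number more inhibition at the concentration tested (going by the name of the read-out):
Compound 1 `CC1=C(C(=O)OC2CCC2)C(c2ccco2)NC(=O)N1` gives 1%.
Compound 2 `CC1=C(C(=O)OC2CCCC2)C(c2ccco2)NC(=O)N1` gives 14%.
Compound 3 `CC1=C(C(=O)OC2CCC2)C(c2ccsc2)NC(=O)N1` gives 3%.

Compound 4 `CC1=C(C(=O)OC2CCCC2)C(c2ccsc2)NC(=O)N1` has not yet been tested in this assay. Compound 2 differs from compound 1 in one place (cyclopentyl in place of cyclobutyl on an oxygen next to a carbonyl group), and that change gave a step of a number 13 percentage points higher from compound 1 to compound 2 (beyond the scatter). Compound 3 differs from compound 1 in its core (thiophen-3-yl in place of furan-2-yl on a saturated ring carbon), a change that gave a number 2 percentage points higher from compound 1 to compound 3 (within the scatter). Compound 4 differs from compound 3 by exactly the same change at exactly the same place (cyclopentyl in place of cyclobutyl on an oxygen next to a carbonyl group), now made on the core of compound 3. Because the earlier step of a number 13 percentage points higher from compound 1 to compound 2 (beyond the scatter) was modest but beyond the scatter, a step of about that size is expected again. Resting on that single earlier example, the expected step is a number 13 percentage points higher from compound 3 to compound 4 (beyond the scatter). Compound 4 is thus estimated at 16%, with a likely range from 5% to 30%.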

Compound 4, a percentage reported as inhibition, at one concentration (the size of the read-out at that concentration, not a potency): 5%
Compound 4: middle estimate off by 11 percentage points, on the high side, within the range that was stated.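

On the core of compound 3, cyclopentyl in place of cyclobutyl gives a number 2 percentage points higher from compound 3 to compound 4 (within the scatter), and set beside the same change on the core of compound 1, the two steps do not differ measurably: the same change on two cores in this assay, a number 13 percentage points higher (beyond the scatter) from compound 1 to compound 2 and a number 2 percentage points higher (within the scatter) from compound 3 to compound 4, 11 percentage points apart, within the scatter of two such steps. Thiophen-3-yl in place of furan-2-yl gives a number 9 percentage points lower from compound 2 to compound 4 (within the scatter), and this step likewise matches its earlier counterpart: the same change on two cores in this assay, a number 2 percentage points higher (within the scatter) from compound 1 to compound 3 and a number 9 percentage points lower (within the scatter) from compound 2 to compound 4, 11 percentage points apart, within the scatter of two such steps. So neither change shows a dependence on the core, yet this does not prove that the gain carries over, as only the step from compound 1 to compound 2 lies beyond the scatter and just one pair of cores is compared.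

The compounds shown leave open how this assay would respond to a cyclohexyl group or a longer chain on that oxygen. They also leave open the effect of an amine or a carboxylic acid on the ring carrying the furan-2-yl or thiophen-3-yl group.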